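Steryl-sulfatase series: amine side chain at compound 2

The compounds below may be only part of what the source reports. "The series", "measured", "known", "first", "only" and "open" are said of these compounds alone.

Measured compounds in an assay on HEK293 cells for inhibition of Steryl-sulfatase (Homo sapiens), tested at 0.1 uM; a higher number here means a stronger effect of the compound at the concentration tested, a lower number a weaker effect:
- compound 1 `NS(=O)(=O)Oc1ccc2c(c1)CN(C(=O)c1cccc(N3CCC(N4CCCCC4)CC3)c1)CC2` gives 0%
- compound 2 `CCN(Cc1ccccc1)c1cccc(C(=O)N2CCc3ccc(OS(N)(=O)=O)cc3C2)c1` gives 17.3%
- compound 3 `CCN(Cc1ccc(Br)cc1)c1cccc(C(=O)N2CCc3ccc(OS(N)(=O)=O)cc3C2)c1` gives 24.2%

Compound 2 stands second of the three numbers. Its nearest neighbour is compound 3, reached by a number 6.9 percentage points higher from compound 2 to compound 3 (within the scatter), a step within the scatter; furthest is compound 1, whose value lies beyond the scatter below that of compound 2.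

The next compound, compound 4 `CN(C)CCCN(Cc1ccccc1)c1cccc(C(=O)N2CCc3ccc(OS(N)(=O)=O)cc3C2)c1`, differs from compound 2 by (dimethylamino)methyl in place of hydrogen on a saturated chain carbon, two bonds along the chain from a nitrogen on an aromatic ring; read one bond further out, ethyl becomes 3-(dimethylamino)propyl. Within the data shown here, no measured step covers this change. Among the measured compounds shown here, the only step recorded, from compound 2 to compound 3, concerns a bromo on an aromatic carbon and stayed within the scatter, so it gives no direction here. For the measured compounds named here, compound 1 carries a different amine on the aromatic nitrogen and gave the lowest value, but no single step links it to compound 2.

With nothing to push the number either way, the expected step of a number 2.3 percentage points lower from compound 2 to compound 4 (within the scatter) is none beyond the scatter. Compound 4 is therefore estimated at 15%, with a range from 0% to 35%.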

Compound 4, a percentage reported as inhibition, at one concentration (the size of the read-out at that concentration, not a potency): 23.8%
Estimate against measurement, compound 4: 8.8 percentage points below, and the stated range covers the measured number.
By their numbers in this assay, from the lowest: compound 1; then compounds 2, 4 and 3 (each within the scatter of the next).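

At the saturated chain carbon two bonds along the chain from a nitrogen on an aromatic ring, in this assay, (dimethylamino)methyl in place of hydrogen gives a number 6.5 percentage points higher from compound 2 to compound 4 (within the scatter) and so leaves the read-out within the scatter. Ethyl can therefore become 3-(dimethylamino)propyl on this nitrogen with no step beyond the scatter, a reading on the chain itself that the bromo step on an aromatic carbon could not supply. No evidence is available that bears on this result.

From the compounds shown here alone, whether a carboxylic acid or a morpholine at the end of this chain would give a step beyond the scatter remains open. Also open, going by these compounds, is whether a longer chain carrying the same dimethylamino group would do so.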